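Replacing 3-methylphenyl with hydroxymethyl on the core of compound 1

A few compounds are considered here, and "the series" means these few. Any claim that something is new, unique, unknown or untested is made for them only; others in the source may bear on it.

Going by the values given here, compound 1 `C/C(=N\Cc1cccc(C)c1)c1c(O)c2ccccc2oc1=O` is the one compound here that yields a number: in an assay on isolated protein for inhibition of myosin-2 (Bos taurus), read by spectrophotometry, with a stated time of 24 min (on this read-out lower numbers stand for stronger inhibition and higher numbers for weaker inhibition), compound 1 gives 4900 nM. Compound 2 `CC/C(=N\Cc1ccccc1)c1c(O)c2ccccc2oc1=O` reaches only a limit of the assay: in this assay compound 2 gives >= 100000 nM. Compound 3 `C/C(=N\Cc1ccccc1)c1c(O)c2cc([N+](=O)[O-])ccc2oc1=O` likewise reaches only a limit, giving >= 100000 nM in this assay. What the measured set offers is the limit of >= 100000 nM in this assay, at which 2 of the 3 values shown sit. Compound 4 `C/C(=N\CCO)c1c(O)c2ccccc2oc1=O` has not been measured; it differs from compound 1 by hydroxymethyl in place of 3-methylphenyl on a saturated chain carbon bound to a double-bonded nitrogen. Among the compounds with values here, no step between measured compounds is available, so the expectation rests on the change alone. The step of a 6.1-fold higher number from compound 1 to compound 4 (0.79 log units; beyond the scatter) is expected to run toward weaker inhibition, beyond the usual scatter. Compound 4 is therefore estimated at 30000 nM, within 8000 nM to 100000 nM.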

Compound 4, half-maximal inhibitory concentration: 92000 nM
Compound 4: the middle estimate sits 3.1-fold (0.49 log units) below what was measured; the measured number falls inside the stated range.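

In this assay, going by these compounds alone, hydroxymethyl in place of 3-methylphenyl gives a 19-fold higher number from compound 1 to compound 4 (1.27 log units; beyond the scatter), the first step that can be read in this set and a large one toward weaker inhibition. The position on a saturated chain carbon bound to a double-bonded nitrogen is therefore not indifferent to the group it carries. Compound 4 still yields a number, while the other weak readings are limits of the assay: the limit of >= 100000 nM in this assay, at which 2 of the 4 values shown sit.

Within the data shown here, the single step cannot separate the loss of 3-methylphenyl from the arrival of hydroxymethyl. From the compounds shown here alone, how an amine, a carboxylic acid or a longer chain would read at this place remains open.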